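Nitro methylsulfonyl benzamides: a series at the assay limit

The source may hold more compounds than are shown below. What is called first, only, known or untested is meant among the compounds shown, and "the series" means these compounds.

Measured so far:
compound 1 `Cc1ccc(N2CCN(C(=O)CCCNC(=O)c3ccc(S(C)(=O)=O)c([N+](=O)[O-])c3)CC2)cc1` > 60000 nM
compound 2 `CN(Cc1ccccc1F)C(=O)C1CCN(C(=O)c2ccc(S(C)(=O)=O)c([N+](=O)[O-])c2)CC1` > 60000 nM
compound 3 `CS(=O)(=O)c1ccc(C(=O)NCCC(=O)N2CCCCC2)cc1[N+](=O)[O-]` > 60000 nM

All three compounds share the nitro methylsulfonyl benzamide core and were tested in an assay on isolated protein for inhibition of thyroid hormone receptor beta (Homo sapiens), read by fluorescence polarization; a lower number here means a stronger inhibitor, a higher number a weaker inhibitor. For compound 1 the value is a limit of the assay, not a number. For compound 2 the value is likewise a limit of the assay. For compound 3 too the value is a limit, not a number. Among the measured compounds shown here, in short, (the limit of > 60000 nM in this assay, at which 3 of the 3 values shown sit), so no compound here gives a measurable number, and no step between measured compounds can be drawn.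

Compound 4 `CN(Cc1ccccc1)C(=O)C1CCN(C(=O)c2ccc(S(C)(=O)=O)c([N+](=O)[O-])c2)CC1` is the next compound, not yet tested in this assay. It differs from compound 2 in one place: hydrogen in place of fluoro on an aromatic carbon.

With compound 2 at a limit and every other compound in the set also at a limit, no step beyond the scatter is expected in this assay from so small a change; the step from compound 2 to compound 4 is estimated at a step that the limit leaves unreadable from compound 2 to compound 4. Compound 4 is therefore expected to give about 80000 nM, within 30000 nM to 300000 nM, most likely reported again only as a limit.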

Compound 4, half-maximal inhibitory concentration: > 60000 nM
Compound 4 was reported as a limit (the forecaster's own chance of this, stated with the estimate: 90%); the middle value does not contradict the limit.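

No step can be read from compound 2 to compound 4 in this assay, since both values are limits and not numbers: the limit of > 60000 nM in this assay, at which 4 of the 4 values shown sit.

The compounds shown leave open what hydrogen in place of fluoro does here, and whether any compound with the shared core gives a measurable number in this assay.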